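Swapping a Pyridine Ring for Chlorophenyl on a Hydroxamic Acid Core

The source may report more compounds than this note shows. Statements on the series, on what has been measured and on what is new or still open speak of the compounds shown alone.

Of the compounds shown here, three sharing one core have been measured in an assay on Sf9 cells for inhibition of protein deacetylase HDAC6 (Homo sapiens), read by fluorescence, with a stated time of 40 min, tested at 100 nM; on this read-out lower numbers stand for less inhibition and higher numbers for more inhibition at the one concentration tested (going by the name of the read-out). Compound 1 `O=C(NO)c1ccc(NCc2nc(-c3ccc(Br)o3)nn2-c2ccccc2)cc1` gives 55.8%, compound 2 `COc1ccc(-c2nc(CNc3ccc(C(=O)NO)cc3)n(-c3ccccc3)n2)cc1` gives 77.6%, and compound 3 `O=C(NO)c1ccc(NCc2nc(-c3cccnc3)nn2-c2ccccc2)cc1` gives 57.7%. Compound 3 is second of the three in this assay: its number sits close to that of compound 1, with a number 1.9 percentage points higher from compound 1 to compound 3 (within the scatter), while compound 2 stands clearly higher, as seen in a number 19.9 percentage points lower from compound 2 to compound 3 (beyond the scatter).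

Compound 4 `O=C(NO)c1ccc(NCc2nc(-c3cccc(Cl)c3)nn2-c2ccccc2)cc1` differs from compound 3 in one place: 3-chlorophenyl in place of pyridin-3-yl on an aromatic carbon. The new group is a carbon-only six-membered ring carrying a chlorine, so the step resembles the move from a ring with one nitrogen to the carbon-only ring of compound 2, where a number 19.9 percentage points lower from compound 2 to compound 3 (beyond the scatter) shows the difference. For the measured compounds named here, no measured step carries a chlorophenyl group, so how much of that gain carries over is uncertain, and the change from compound 1 to compound 3, a number 1.9 percentage points higher from compound 1 to compound 3 (within the scatter), shows that exchanging rings in this position can also leave the number unchanged.

A modest rise is expected for compound 4, estimated at a number 8.3 percentage points higher from compound 3 to compound 4 (within the scatter). Compound 4 is thus expected to give 66% in this assay, within a range from 52% to 80%.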

Compound 4, a percentage reported as inhibition, at one concentration (the size of the read-out at that concentration, not a potency): 61.2%
For compound 4 the middle estimate is 4.8 percentage points above the measured one; the measured number falls inside the stated range.
By their numbers in this assay, from the lowest: compounds 1, 3 and 4 (each within the scatter of the next); then compound 2.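

In this assay, replacing the pyridin-3-yl ring with a carbon-only ring carrying a chlorine does not produce a difference that can be told from the scatter (a number 3.5 percentage points higher from compound 3 to compound 4 (within the scatter)), and the same holds for the exchange of 5-bromofuran-2-yl for 3-chlorophenyl (a number 5.4 percentage points higher from compound 1 to compound 4 (within the scatter)). Compound 2 stays apart (a number 16.4 percentage points lower from compound 2 to compound 4 (beyond the scatter)), so having a carbon-only six-membered ring at this position is not enough on its own to reach the number given by the 4-methoxyphenyl group, and among these compounds only that group stands out from the rest. The data offer no measurement that would explain why this one group differs from the other three.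

Going by these compounds, the step from compound 3 to compound 4 changes two things at once, the ring nitrogen and the chlorine, so their separate contributions remain unknown, and an unsubstituted phenyl group would be needed to pull them apart. On these data alone, it also remains open how this position would respond to a ring carrying an amine or a carboxylic acid.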